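This account rests on a few compounds, and the source may have more. Where it says the series, first, only, none or still open, it means among the compounds named here.

Among the measured compounds shown here, compound 1 `CC(C(=O)N1CCN(c2cccc(Cl)c2)CC1)N1C(=O)CCC1=O` in a functional assay on the whole organism (strain Swiss) with Mus musculus as the target, in the maximal electroshock model, with a stated time of 0.25 h, at a dose of 100 mg/kg by the intraperitoneal route (a higher number here means a stronger effect of the compound at the dose given, a lower number a weaker effect), gives 50%, the lower of the two numbers measured so far. Compound 2 `CC(C(=O)N1CCN(c2ccccc2F)CC1)N1C(=O)CCC1=O` in this assay gives 75%; the step of a number 25 percentage points higher from compound 1 to compound 2 (beyond the scatter) exchanges the whole aryl group on the amine nitrogen in the ring. Compound 3 `CC(C(=O)N1CCN(c2cccc(C(F)(F)F)c2)CC1)N1C(=O)CCC1=O` differs from compound 1 only by trifluoromethyl in place of chloro on an aromatic carbon. For the measured compounds named here, no measured step replaces one group by another on the same aryl ring, so the step to compound 2 bears on this change only loosely, and no movement beyond the scatter is expected. The expected step is no change at the digits printed from compound 1 to compound 3 (within the scatter). Compound 3 is estimated at 50%, with a range from 25% to 75%.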

Compound 3, a percentage reported as activity, at one dose (the size of the read-out at that dose, not a potency): 50%
Estimate against measurement, compound 3: no gap at the digits printed, and the stated range covers the measured number.
By their numbers in this assay, from the lowest: compounds 1 and 3 (each within the scatter of the next); then compound 2.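

In this assay, the change shows no change at the digits printed from compound 1 to compound 3 (within the scatter): on this aromatic carbon, meta to a large group, trifluoromethyl and chloro cannot be told apart at this single dose. The earlier step exchanged the whole aryl group, so it could not show this. No measurement given here offers an explanation for this result.

On these data alone, whether a methoxy group, an amine or a carboxylic acid on this carbon would hold the read-out remains open. So does whether trifluoromethyl and chloro would remain indistinguishable at other doses.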